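From naphthalen-2-yl to 3,5-difluorophenyl on the carbonyl

The source may hold more compounds than are shown below. What is called first, only, known or untested is meant among the compounds shown, and "the series" means these compounds.

In a functional assay on A2780 cells (Homo sapiens) for antiproliferative activity, read by fluorescence, with a stated time of 72 h (on this read-out higher numbers stand for weaker inhibition and lower numbers for stronger inhibition), compound 1 `CN1CCC(C(=O)N2Cc3c(NC(=O)NCc4ccccc4)n[nH]c3C2(C)C)CC1` gives 2680 nM, while compound 2 `CN1CCC(C(=O)N2Cc3c(NC(=O)c4ccc5ccccc5c4)n[nH]c3C2(C)C)CC1` gives 270 nM, the lower of the two numbers. Compound 3 `CN1CCC(C(=O)N2Cc3c(NC(=O)c4cc(F)cc(F)c4)n[nH]c3C2(C)C)CC1` carries 3,5-difluorophenyl in place of naphthalen-2-yl on a carbonyl carbon. Among the compounds with values here, only one measured step bears on this change: a 9.9-fold lower number from compound 1 to compound 2 (1.00 log units; beyond the scatter), a modest step that also fell on the carbonyl carbon but replaced benzylamino, so it offers limited guidance. The expected change is small, a slightly higher number within the scatter, and the estimated step is a 1.3-fold higher number from compound 2 to compound 3 (0.11 log units; within the scatter). Compound 3 is expected at 350 nM, with an estimated range of 110 nM to 1100 nM.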

Compound 3, half-maximal inhibitory concentration: 130 nM
Compound 3: middle estimate off by 2.7-fold (0.43 log units), on the high side, within the range that was stated.
By their numbers in this assay, from the lowest: compound 3; then compound 2; then compound 1.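

In this assay, 3,5-difluorophenyl on the carbonyl carbon, with one aromatic ring, goes beyond naphthalen-2-yl, with two, giving a 2.1-fold lower number from compound 2 to compound 3 (0.32 log units; beyond the scatter), so a low number at this position does not require the second ring. Set against benzylamino, the same group gives a 21-fold lower number from compound 1 to compound 3 (1.31 log units; beyond the scatter), the largest step among these compounds. Nothing measured here explains why the number falls with this change. On these data alone, whether the two fluorines matter remains open, and a plain phenyl would be the direct comparison. As far as these compounds go, how an amine or a carboxylic acid on that ring would read also stays unknown.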